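Naphthalenyl in place of isobutyl: acid dissociation expected

A few compounds are considered here, and "the series" means these few. Any claim that something is new, unique, unknown or untested is made for them only; others in the source may bear on it.

The account follows a small set sharing the core of compound 1 `CC(C)Cc1ccc2c(NCCCNCc3ccco3)ccnc2c1`, which in a physicochemical assay for acid dissociation, gives 9.47. Compound 2 `COc1ccc(F)cc1CNCCCNc1ccnc2cc(CC(C)C)ccc12` gives 9.47 in this assay, and compound 3 `COc1ccc(F)cc1CNCCCNc1ccnc2cc(Cc3ccc(F)cc3)ccc12` gives 9.47. Compound 1 thus stands level with compounds 2 and 3 at the digits shown; its gaps to both lie within the usual scatter.

Two single-site steps have been measured. The first, 5-fluoro-2-methoxyphenyl in place of furan-2-yl on a saturated chain carbon bound to an amine nitrogen, gave no change at the digits printed from compound 1 to compound 2 (within the scatter). The second, 4-fluorophenyl in place of isopropyl on a saturated chain carbon bound to an aromatic carbon, gave no change at the digits printed from compound 2 to compound 3 (within the scatter).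

Compound 4 `c1coc(CNCCCNc2ccnc3cc(-c4cccc5ccccc45)ccc23)c1` has not yet been measured. Its difference from compound 1 is naphthalen-1-yl in place of isobutyl on an aromatic carbon. Within the data shown here, no measured step alters exactly this site, so there is no direct precedent; the second step, however, also changed the group carried on the core and left the value unmoved within the scatter. On that basis the step from compound 1 to compound 4 is expected to be no change at the digits printed from compound 1 to compound 4 (within the scatter), that is, nothing beyond the scatter. Compound 4 is accordingly estimated at 9.47, with a range from 9.17 to 9.77.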

Compound 4, acid dissociation constant: 9.47
For compound 4 middle estimate and measured number coincide at the digits printed, and the stated range covers the measured number.
By their numbers in this assay, from the lowest: compounds 1, 2, 3 and 4 (each within the scatter of the next).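

In this assay, exchanging isobutyl, with 4 heavy atoms and no ring, for naphthalen-1-yl, with 10 heavy atoms and 2 six-membered aromatic rings of carbon only, gave no change at the digits printed from compound 1 to compound 4 (within the scatter). The earlier step on the core, from isopropyl to 4-fluorophenyl, had kept a saturated chain carbon bound to the aromatic carbon, whereas this change places an aromatic ring directly on that aromatic carbon, on the six-membered aromatic ring of carbon only that is part of the fused system of two rings, and so it extends the flat result to a much larger group attached in a different way. Nothing available explains why the reading holds across this change.

As far as these compounds go, both groups compared at this place are made of carbon alone, with no hydrogen-bond donors or acceptors, so what an amine or a carboxylic acid on the same aromatic carbon would do to the reading remains open. All four compounds read alike, so the shown set also gives no single-site change that moves the value beyond the scatter, and it cannot tell which structural changes, if any, would do so.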